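Fluoro in Place of Hydrogen on a Second Core

A few compounds are considered here, and "the series" means these few. Any claim that something is new, unique, unknown or untested is made for them only; others in the source may bear on it.

Measured so far in a functional assay on HeLa cells (Homo sapiens) for cytotoxicity, read by MTT assay, with a stated time of 72 h, tested at 10 uM; on this read-out lower numbers stand for less inhibition of growth and higher numbers for more inhibition of growth at the one concentration tested:

compound 1, `N/C(=N\NC(=S)N1CCCCCC1)c1ccccn1`: 67.4%
compound 2, `N/C(=N\NC(=S)N1CCOCC1)c1ccccn1`: 56.3%
compound 3, `N/C(=N\NC(=S)N1CCOCC1)c1ccc(F)cn1`: 81.9%

Compound 1 and compound 2 share a large part of their structure, but the difference between the two cores is not broken down here; their values simply show compound 1 above compound 2 in this assay. Compound 2 and compound 3 differ in one place: fluoro in place of hydrogen on an aromatic carbon. This single change produced a number 25.6 percentage points higher from compound 2 to compound 3 (beyond the scatter).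

Compound 4, `N/C(=N\NC(=S)N1CCCCCC1)c1ccc(F)cn1`, has not yet been measured. It stands to compound 1 exactly as compound 3 stands to compound 2: fluoro in place of hydrogen on an aromatic carbon. The change is the same, at the same place, only on the core of compound 1 instead of the core of compound 2.

The expectation rests on that one earlier instance. A rise of the full earlier size cannot be assumed, because compound 1 already starts from 67.4% and the read-out cannot run far above full inhibition of growth. Compound 4 is therefore expected to give about 85%, most likely between 70% and 97%. That would be an expected step of a number 17.6 percentage points higher from compound 1 to compound 4 (beyond the scatter), somewhat smaller than the step seen from compound 2 to compound 3.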

Compound 4, percent growth inhibition at one concentration: 83.2%
Beside the measured number, compound 4's estimate is 1.8 percentage points above it; the measured number falls inside the stated range.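

Putting fluoro in place of hydrogen on an aromatic carbon of the core of compound 1 gave, in this assay, a number 15.8 percentage points higher from compound 1 to compound 4 (beyond the scatter). This shows that the change carried over to a second core in the same direction, but two cores are too few to show that it would do so on every core in this series, and the data do not explain why the number rises. The two steps also cannot be told apart in size, so there is no sign here that one core responds more strongly than the other: the same change on two cores in this assay, a number 25.6 percentage points higher (beyond the scatter) from compound 2 to compound 3 and a number 15.8 percentage points higher (beyond the scatter) from compound 1 to compound 4, 9.8 percentage points apart, within the scatter of two such steps

Fluoro is the only group shown at this place, so it remains open whether a chloro, methyl or methoxy group there would raise the number in the same way. Going by these compounds, it also remains open whether fluoro elsewhere on the aromatic ring would do so, or whether the step would hold on a core carrying an amine or a carboxylic acid.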